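The compounds below may be only part of what the source reports. "The series", "measured", "known", "first", "only" and "open" are said of these compounds alone.

The measured compounds are these:

compound 1, `Cn1cc(NC(=O)c2cnc3ccc(N4CCC[C@@H](N)C4)nn23)c(C(F)F)n1`: 41700 nM
compound 2, `Cn1cc(NC(=O)c2cnc3ccc(N[C@@H]4CCNC4)nn23)c(C(F)F)n1`: > 50000 nM, a limit of the assay

In a functional assay on HT cells (Homo sapiens) for cytotoxicity, read by CCK-8 assay, with a stated time of 72 h (on this read-out lower numbers stand for stronger inhibition and higher numbers for weaker inhibition), compound 1 gives 41700 nM. For compound 2 this assay reports only the limit > 50000 nM, so no number is known for it; compound 2 stands at or beyond the edge of what this assay can resolve, as the limit of > 50000 nM in this assay, at which 1 of the 2 values shown sits, shows. Among the compounds with values here, the one measured step, an at least 1.1-fold higher number from compound 1 to compound 2 (0.07 log units; that floor lies within the scatter), lies within the scatter, so nothing beyond the scatter separates compound 1 from compound 2.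

Compound 3, `Cn1cc(NC(=O)c2cnc3ccc(NCCN)nn23)c(C(F)F)n1`, is not yet measured in this assay. It differs from compound 2 in one place: 2-aminoethyl in place of pyrrolidin-3-yl on a nitrogen on an aromatic ring. Within the data shown here, no measured step concerns this exchange, so the only bearing comes from the position of compound 2 itself, which is a limit. Since both measured compounds sit at very high numbers, compound 3 is expected to sit there as well, with the step of a number no higher from compound 2 to compound 3 (the limit leaves the size open) expected to stay within the scatter. Compound 3 is therefore estimated at 50000 nM, with a range from 20000 nM to 150000 nM, and a further limit reading is the likeliest outcome.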

Compound 3, half-maximal inhibitory concentration: > 50000 nM
Compound 3 was reported as a limit; the forecaster's own chance of this, stated with the estimate: 70%; the middle value sits exactly at the limit.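

In this assay compound 3 is reported only as a limit, > 50000 nM. So the open-chain 2-aminoethyl on a nitrogen on an aromatic ring, in place of the pyrrolidin-3-yl ring with its defined stereocentre, also yields no number, and its step from the compound carrying that ring cannot be read because both ends are limits: the limit of > 50000 nM in this assay, at which 2 of the 3 values shown sit. Within the data shown here, the only step that can be read is an at least 1.1-fold higher number from compound 1 to compound 3 (0.07 log units; that floor lies within the scatter), so (2-aminoethyl)amino in place of 3-aminopiperidin-1-yl shows nothing beyond the scatter.

All three groups shown carry an amine, whether on a ring or on a short chain, and all three values lie at very high numbers or at the limit in this assay. From the compounds shown here alone, what stays open is whether a longer chain such as 3-aminopropyl, or a group without an amine such as a methoxy group or a carboxylic acid, would read any differently in the same place on the shared core.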